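Oxadiazole in Place of Methoxy on the Biaryl

This account rests on a few compounds, and the source may have more. Where it says the series, first, only, none or still open, it means among the compounds named here.

Compound 2 `COc1cccc(-c2ccc(C(=O)N(Cc3cccc(OCCCCCC(=O)O)c3)C(C)C)cc2)c1` stands only at a limit on the numbers shown: in an ADME assay on HEK293 cells (Homo sapiens) for cytotoxicity, read by CellTiter-Glo and resazurin assay, with a stated time of 72 h (a lower number here means that less compound is needed, a higher number that more compound is needed for the effect), compound 2 gives > 20900 nM, a limit of the assay and not a number. Compound 1 `CC(C)N(Cc1cccc(OCCCCCC(=O)O)c1)C(=O)c1ccc(-c2cccc(OCc3ccccc3)c2)cc1` likewise gives a limit in this assay, > 26000 nM. Between them the step that the two limits leave unreadable from compound 1 to compound 2 is unreadable. Compound 3 `Cc1nnc(-c2cccc(-c3ccc(C(=O)N(Cc4cccc(OCCCCCC(=O)O)c4)C(C)C)cc3)c2)o1` differs from compound 2 by 5-methyl-1,3,4-oxadiazol-2-yl in place of methoxy on an aromatic carbon. No readable step bears on this change, so one expects a step that the limit leaves unreadable from compound 2 to compound 3, not beyond the scatter, and most likely another limit. Compound 3 is accordingly estimated at 30000 nM, between 10000 nM and 100000 nM.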

Compound 3, half-maximal effective concentration: > 26000 nM
Compound 3: only a limit was reported (the forecaster's own chance of this, stated with the estimate: 85%); the middle value does not contradict the limit.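

In this assay compound 3 gives > 26000 nM as a limit of the assay and not a number, so the steps among compound 1, compound 2 and compound 3 cannot be read. The compounds shown leave open the actual half-maximal effective concentration of each, and so whether 5-methyl-1,3,4-oxadiazol-2-yl in place of methoxy changes it at all.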